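The source may hold more compounds than are shown below. What is called first, only, known or untested is meant among the compounds shown, and "the series" means these compounds.

Measured so far in a functional assay on DU-145 cells (Homo sapiens) for antiproliferative activity, read by MTT assay, with a stated time of 24 h; a higher number here means a weaker inhibitor, a lower number a stronger inhibitor:
- compound 1, `COc1cc(-c2cc(C(=O)/C=C/c3ccc(C)cc3)nc3cc(-c4ccccc4)nn23)cc(OC)c1OC`: 21900 nM
- compound 2, `COc1cc(-c2cc(/C=C/C(=O)c3ccc(C)cc3)nc3cc(-c4ccccc4)nn23)cc(OC)c1OC`: 27100 nM
- compound 3, `COc1cc(-c2cc(/C=C/C(=O)c3ccc(Cl)cc3)nc3cc(-c4ccccc4)nn23)cc(OC)c1OC`: 29300 nM

Compound 3 carries the highest of the three numbers in this assay, but only by margins that do not separate it from the others: the step of a 1.1-fold higher number from compound 2 to compound 3 (0.03 log units; within the scatter) and the step of a 1.3-fold higher number from compound 1 to compound 3 (0.13 log units; within the scatter) both lie within the scatter, so the three compounds cannot be told apart on these data. Among the compounds with values here, the shared core is kept throughout, and the variation so far touches the enone arm and the substituent of the six-membered aromatic ring at its end.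

Compound 4, `COc1cc(-c2cc(/C=C/C(=O)c3ccccc3)nc3cc(-c4ccccc4)nn23)cc(OC)c1OC`, is the next member, differing from compound 3 by hydrogen in place of chloro on an aromatic carbon. Within the data shown here, the one measured step that bears directly on this position is a 1.1-fold higher number from compound 2 to compound 3 (0.03 log units; within the scatter), a swap of one substituent for another at the same aromatic carbon, which stayed within the scatter. Rearranging the enone arm, a 1.2-fold higher number from compound 1 to compound 2 (0.09 log units; within the scatter), was likewise flat. Nothing in the series shows the para substituent of that ring moving the number, so for compound 4 no step beyond the scatter is expected. Compound 4 is therefore estimated at 27000 nM, with a range of 13000 nM to 56000 nM, corresponding to an expected step of a 1.1-fold lower number from compound 3 to compound 4 (0.04 log units; within the scatter).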

Compound 4, half-maximal inhibitory concentration: 34300 nM
For compound 4 the middle estimate is 1.3-fold (0.10 log units) below the measured one; the measured number falls inside the stated range.
By their numbers in this assay, from the lowest: compounds 1, 2, 3 and 4 (each within the scatter of the next).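

In this assay, the aromatic carbon para to a large group now has a comparison with no substituent there, not only an exchange of one substituent for another: hydrogen in place of chloro (a 1.2-fold higher number from compound 3 to compound 4 (0.07 log units; within the scatter)) and hydrogen in place of methyl (a 1.3-fold higher number from compound 2 to compound 4 (0.10 log units; within the scatter)) both stay within the scatter, so 4-chlorophenyl, 4-methylphenyl and phenyl at the end of the arm cannot be told apart on these data. Within the data shown here, the change to 2-benzoylethenyl from (2-(4-methylphenyl)ethenyl)carbonyl (a 1.6-fold higher number from compound 1 to compound 4 (0.19 log units; within the scatter)) alters the enone arm and removes the methyl at once, and it also stays within the scatter, so the series still holds no step that separates any two compounds. No measured evidence accompanies these numbers that could account for this flat picture.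

Open, on these data alone, is whether a different kind of group at this carbon, such as an amine or a carboxylic acid, would give a step beyond the scatter. Also open, as far as these compounds go, is whether any change to the shared core, which all four compounds keep, would move the number at all.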